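The compounds below may be only part of what the source reports. "The series", "measured", "known", "first", "only" and "open" are said of these compounds alone.

In a functional assay on isolated protein for inhibition of Glucose-dependent insulinotropic receptor (Homo sapiens), read by HTRF and cAMP accumulation (on this read-out higher numbers stand for an effect only at larger amounts of compound and lower numbers for an effect already at smaller amounts), compound 1 `Cc1nc(S(C)(=O)=O)ccc1Oc1ncnc(OC2CCN(C(=O)OC(C)C)CC2)c1F` gives 21 nM, and compound 2 `CCC1(OC(=O)N2CCC(Oc3ncnc(Oc4ccc(S(C)(=O)=O)nc4C)c3F)CC2)CC1` gives 22 nM. Within the data shown here, the one step measured between them, a 1.0-fold higher number from compound 1 to compound 2 (0.02 log units; within the scatter), shows that swapping one of these two groups for the other left the result within the scatter. Compound 2 thus stands at the higher of the two numbers, but only by a margin that means nothing. Compound 3 `Cc1nc(S(C)(=O)=O)ccc1Oc1ncnc(OC2CCN(C(=S)OC(C)C)CC2)c1F` differs from compound 2 as follows: a group of 6 heavy atoms (4 carbon, 1 oxygen, 1 sulfur; no ring) in place of a group of 8 heavy atoms (6 carbon, 2 oxygen; one three-membered non-aromatic ring of carbon only), on an amine nitrogen in a ring. The measured step bears on this only in part, since it changed the same region of the molecule but not the atom that is exchanged here; nothing measured speaks to that exchange. Without evidence of an effect, the expected step of a 1.1-fold higher number from compound 2 to compound 3 (0.06 log units; within the scatter) is none beyond the scatter, with a wider range to allow for the untested exchange. Compound 3 is therefore expected to give about 25 nM, somewhere between 9 nM and 70 nM.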

Compound 3, half-maximal effective concentration: 69.9 nM
Compound 3: middle estimate off by 2.8-fold (0.45 log units), on the low side; low and high end bracket the measured number.
By their numbers in this assay, from the lowest: compounds 1 and 2 (each within the scatter of the next); then compound 3.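

In this assay, putting a sulfur where the isopropyl compound has its second oxygen gives a 3.3-fold higher number from compound 1 to compound 3 (0.52 log units; beyond the scatter) and is the cleanest view of this exchange, since the group on the amine nitrogen otherwise stays the same. Among these compounds, the alkyl swap between compounds 1 and 2 stayed within the scatter, so this is the first change at this position that clearly moves the number. The comparison with the 1-ethylcyclopropyl compound gives a 3.2-fold higher number from compound 2 to compound 3 (0.50 log units; beyond the scatter) and points the same way, though there the alkyl part differs as well. The data shown offer no measurement that explains the shift.
As far as these compounds go, whether sulfur has a similar effect alongside 1-ethylcyclopropyl remains open. So does the outcome of a urea, with a nitrogen in place of the oxygen that carries the isopropyl.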